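Changing the piperidine substituent in a GIP receptor agonist series

The compounds below may be only part of what the source reports. "The series", "measured", "known", "first", "only" and "open" are said of these compounds alone.

Compound 2 `CS(=O)(=O)c1cnc(O[C@H]2CC[C@H](OC3CCN(C(=O)OC4CCOC4)CC3)CC2)cn1` gives 1500 nM in a functional assay on isolated protein for agonist activity at Glucose-dependent insulinotropic receptor (Rattus norvegicus), read by HTRF and cAMP accumulation (a lower number here means that less compound is needed, a higher number that more compound is needed for the effect), the highest of the two numbers recorded; compound 1 `CC(C)(C)OC(=O)N1CCC(O[C@H]2CC[C@H](Oc3cnc(C#N)cn3)CC2)CC1` gives 28.4 nM, a gap beyond the scatter. Compound 3 `CS(=O)(=O)c1cnc(O[C@H]2CC[C@H](OC3CCN(CC4(C(F)(F)F)CCCC4)CC3)CC2)cn1` differs from compound 2 in one place: a group of 10 heavy atoms (7 carbon, 3 fluorine; one five-membered non-aromatic ring of carbon only) in place of a group of 8 heavy atoms (5 carbon, 3 oxygen; one five-membered non-aromatic ring with 1 hetero atom), on an amine nitrogen in a ring. Among the measured compounds shown here, no directly comparable step between measured compounds exists, and compound 1 differs from compound 2 at two sites, so the size of the step is uncertain. A modest lowering of the number is expected for compound 3, with wide bounds, as a 2.5-fold lower number from compound 2 to compound 3 (0.40 log units; beyond the scatter). Compound 3 is estimated at 600 nM, expected within 100 nM to 4000 nM.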

Compound 3, half-maximal effective concentration: 101 nM
Compound 3: middle estimate off by 5.9-fold (0.77 log units), on the high side; the range from low to high includes it.
By their numbers in this assay, from the lowest: compound 1; then compound 3; then compound 2.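

On an amine nitrogen in the six-membered ring, replacing ((oxolan-3-yl)oxy)carbonyl with the group of carbon and fluorine gives a 15-fold lower number from compound 2 to compound 3 (1.17 log units; beyond the scatter) in this assay for this pair. The position therefore accepts the loss of the carbonyl and of all hydrogen-bond acceptors in the leaving group without any rise in the number. Nothing measured here explains this step.

The compounds shown do not separate the contribution of the carbon-only ring from that of the fluorine atoms, and a cyclopentylmethyl group on the same nitrogen would address that. On these data alone, whether an amine or a carboxylic acid is accepted at this position also remains open.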